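Chloro for fluoro on the benzamide ring

The compounds below may be only part of what the source reports. "The series", "measured", "known", "first", "only" and "open" are said of these compounds alone.

Three compounds share a sulfonamide-bearing core. Compound 1 `O=C(NS(=O)(=O)c1ccc(NC(=O)c2ccc(Cl)cc2Cl)cc1)c1ccccc1` is a limit case: in a functional assay on HEK293 cells for agonist activity at probable G-protein coupled receptor 27 (Homo sapiens), read by a luciferase reporter and beta-arrestin recruitment, with a stated time of 10 min (on this read-out lower numbers stand for an effect already at smaller amounts and higher numbers for an effect only at larger amounts of compound), compound 1 gives > 100000 nM, which is a limit of the assay and not a number. Among the measured compounds shown here, compound 2 `O=C(Nc1ccc(S(=O)(=O)Nc2cccc(Cl)c2)cc1)c1ccc(Cl)cc1Cl` gives 575 nM in this assay, and the step of an at least 170-fold lower number from compound 1 to compound 2 (2.24 log units; beyond the scatter) is the only measured step. Compound 3 `O=C(Nc1ccc(S(=O)(=O)Nc2ccccc2)cc1)c1ccc(Cl)cc1F` gives 3980 nM in this assay, the highest of the two numbers, with compound 2 its nearest neighbour at a markedly lower value.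

Compound 4 `O=C(Nc1ccc(S(=O)(=O)Nc2ccccc2)cc1)c1ccc(Cl)cc1Cl` differs from compound 3 by chloro in place of fluoro on an aromatic carbon, on an aromatic carbon ortho to a large group and meta to a chloro group. For the measured compounds named here, no measured step touches this position; the step from compound 1 to compound 2 changes the sulfonamide nitrogen instead and so offers no guide. Compound 2 shows what a dichloro pattern can reach, but compound 4 lacks its 3-chlorophenyl, so only a moderate gain is expected: the step of a 2.7-fold lower number from compound 3 to compound 4 (0.42 log units; beyond the scatter) is the estimate. Compound 4 is expected to give 1500 nM, within 400 nM to 6000 nM.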

Compound 4, half-maximal effective concentration: 457 nM
For compound 4 the middle estimate is 3.3-fold (0.52 log units) above the measured one; low and high end bracket the measured number.
By their numbers in this assay, from the lowest: compounds 4 and 2 (each within the scatter of the next); then compound 3. At a limit, above all of these: compound 1.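

In this assay, among the compounds shown here, the change from 4-chloro-2-fluorophenyl to 2,4-dichlorophenyl proves to matter on its own, giving an 8.7-fold lower number from compound 3 to compound 4 (0.94 log units; beyond the scatter), the first measured step at this position. With the 2,4-dichlorophenyl in place, the chloro of the 3-chlorophenyl group adds nothing that can be read, as hydrogen in its place gives a 1.3-fold lower number from compound 2 to compound 4 (0.10 log units; within the scatter). Phenyl in place of benzoyl on the sulfonamide nitrogen gives an at least 210-fold lower number from compound 1 to compound 4 (2.34 log units; beyond the scatter); this is a bound only, the value of compound 1 being a limit: the limit of > 100000 nM in this assay, at which 1 of the 4 values shown sits.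

As far as these compounds go, it remains open whether bromo, methyl or methoxy at this position would follow chloro or fluoro. Also open, from the compounds shown here alone, is whether the step from fluoro to chloro keeps its size when the 3-chlorophenyl group is present.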